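A few compounds are considered here, and "the series" means these few. Any claim that something is new, unique, unknown or untested is made for them only; others in the source may bear on it.

Measured so far:
Compound 1 `CC(C)(C)Cc1csc(N)c1C(=O)c1ccc(Cl)cc1`: 5%
Compound 2 `COc1ccccc1-c1sc(N)c(C(=O)c2ccc(Cl)cc2)c1CC(C)(C)C`: 1%
Compound 3 `Cc1cccc(-c2sc(N)c(C(=O)c3ccc(Cl)cc3)c2CC(C)(C)C)c1`: 1%

In an assay on CHO cells for displacement of a labelled ligand from adenosine receptor A3 (Homo sapiens), read by scintillation counting, tested at 10 uM (a higher number here means more inhibition at the concentration tested (going by the name of the read-out), a lower number less inhibition), compound 3 gives 1%. It stands level with compound 2 and the two together are the lowest of the three numbers, while the step of a number 4 percentage points lower from compound 1 to compound 3 (within the scatter) lies within the scatter, so all three compounds read alike. Among the compounds with values here, compound 4 `CC(C)(C)Cc1c(-c2ccco2)sc(N)c1C(=O)c1ccc(Cl)cc1` keeps the shared core and changes only one group: furan-2-yl in place of 3-methylphenyl on an aromatic carbon. Within the data shown here, the steps that bear on this change are those that put an aromatic group on the same carbon or swap one there: a number 4 percentage points lower from compound 1 to compound 2 (within the scatter), a number 4 percentage points lower from compound 1 to compound 3 (within the scatter) and no change at the digits printed from compound 2 to compound 3 (within the scatter), all within the scatter. No shift beyond the scatter is therefore expected, and compound 4 is estimated at 2%, between -6% and 10%, a step of a number 1 percentage points higher from compound 3 to compound 4 (within the scatter).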

Compound 4, a percentage reported as inhibition, at one concentration (the size of the read-out at that concentration, not a potency): 1%
Compound 4: middle estimate off by 1 percentage points, on the high side; measured number inside the range.
By their numbers in this assay, from the lowest: compounds 2, 3, 4 and 1 (each within the scatter of the next).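

On the carbon next to the ring sulfur, a five-membered aromatic ring with a hetero atom now reads like the six-membered aromatic rings in this assay. The steps are no change at the digits printed from compound 3 to compound 4 (within the scatter) and no change at the digits printed from compound 2 to compound 4 (within the scatter) and also a number 4 percentage points lower from compound 1 to compound 4 (within the scatter) for the parent with hydrogen there. Ring size and the ring oxygen therefore make no visible difference among these compounds. Every group shown at this carbon is hydrogen or an aromatic ring, so an amine, a carboxylic acid or a longer chain there remains open. No measurement shown explains why the numbers stay together.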